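The source may hold more compounds than are shown below. What is called first, only, known or untested is meant among the compounds shown, and "the series" means these compounds.

Compound 2 `CCCCc1cc2cn(COCCO)c(O)nc-2n1` is measured in a functional assay on HEL cells (Homo sapiens), read by microscopy; a higher number here means that more compound is tolerated, a lower number that less compound is tolerated. In this assay compound 2 gives only a limit, > 400000 nM. Its neighbour compound 1 `CCCCCCCc1cc2cn(COCCO)c(O)nc-2n1` likewise gives only a limit in this assay, >= 400000 nM. The step that the two limits leave unreadable from compound 1 to compound 2 is therefore unreadable, both ends resting at limits, the limit of > 400000 nM in this assay, at which 1 of the 2 values shown sits, and (the limit of >= 400000 nM in this assay, at which 1 of the 2 values shown sits). Compound 3 `OCCOCn1cc2ccnc-2nc1O` differs from compound 2 by hydrogen in place of butyl on an aromatic carbon. Among the measured compounds shown here, no measured step speaks to such a change, and with compound 2 sitting at a limit, compound 3 is expected to stay at that limit, an expected step of a number no higher from compound 2 to compound 3 (the limit leaves the size open). Compound 3 is thus estimated at 400000 nM, between 200000 nM and 800000 nM.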

Compound 3, minimum cytotoxic concentration: > 400000 nM
Compound 3: only a limit was reported; the forecaster's own chance of this, stated with the estimate: 85%; the middle value sits exactly at the limit.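

With compound 3 also resting at a limit, the steps to it from compound 1 and compound 2 cannot be read. The compounds shown leave open whether hydrogen, butyl or heptyl on that aromatic carbon makes any difference in this assay.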